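Cyclobutylcarbamoyl step from compound 3

The source may hold more compounds than are shown below. What is called first, only, known or untested is meant among the compounds shown, and "the series" means these compounds.

Measured in a functional assay on LNCaP cells (Homo sapiens) for antiproliferative activity; on this read-out lower numbers stand for stronger inhibition and higher numbers for weaker inhibition:
- compound 1 `Cn1ncc(Cl)c1-c1cc(C(=O)N[C@@H]2CN[C@H](CCN3CCC(O)CC3)C[C@H]2c2ccc(Cl)c(Cl)c2)oc1Cl`: 1140 nM
- compound 2 `Cn1ncc(Cl)c1-c1cc(C(=O)N[C@@H]2CN[C@H](CCN3CCCCC3)C[C@H]2c2ccc(Cl)c(Cl)c2)oc1Cl`: 1780 nM
- compound 3 `Cn1ncc(Cl)c1-c1cc(C(=O)N[C@@H]2CN[C@H](CCN3CCCC3)C[C@H]2c2ccc(Cl)c(Cl)c2)oc1Cl`: 1920 nM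

Compound 3 stands within the scatter of both other compounds, as shown by a 1.1-fold higher number from compound 2 to compound 3 (0.03 log units; within the scatter) and a 1.7-fold higher number from compound 1 to compound 3 (0.23 log units; within the scatter). Compound 4 `Cn1ncc(Cl)c1-c1cc(C(=O)N[C@@H]2CN[C@H](CC(=O)NC3CCC3)C[C@H]2c2ccc(Cl)c(Cl)c2)oc1Cl` is still unmeasured in this assay. It carries cyclobutylcarbamoyl in place of (pyrrolidin-1-yl)methyl on a saturated chain carbon bound to a saturated ring carbon. The nearest evidence is weak, since a 1.6-fold higher number from compound 1 to compound 2 (0.19 log units; within the scatter) and the two steps above stayed within the scatter, and none of them brings in a carbamoyl group. The expected step, a 1.3-fold higher number from compound 3 to compound 4 (0.10 log units; within the scatter), therefore stays within the scatter, with wide uncertainty. For compound 4 the estimate is 2400 nM, with an expected range of 900 nM to 6000 nM.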

Compound 4, half-maximal inhibitory concentration: 80 nM
For compound 4 the middle estimate is 30-fold (1.48 log units) above the measured one; measured number below the stated range.
By their numbers in this assay, from the lowest: compound 4; then compounds 1, 2 and 3 (each within the scatter of the next).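

In this assay, swaps among pyrrolidin-1-yl, piperidin-1-yl and 4-hydroxypiperidin-1-yl left the numbers within the scatter, so this place looked insensitive. Cyclobutylcarbamoyl shows otherwise, with large steps beyond the scatter from all three amines (a 24-fold lower number from compound 3 to compound 4 (1.38 log units; beyond the scatter); a 22-fold lower number from compound 2 to compound 4 (1.35 log units; beyond the scatter); a 14-fold lower number from compound 1 to compound 4 (1.15 log units; beyond the scatter)). Nothing measured here accounts for these steps.

Still open, from the compounds shown here alone, is whether the step depends on the carbonyl, the amide hydrogen or the four-membered ring. A primary amide, a cyclopentyl amide or a carboxylic acid at this place would help to separate these.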